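The compounds below may be only part of what the source reports. "The series", "measured", "known", "first", "only" and "open" are said of these compounds alone.

In a functional assay on BT-474 cells (Homo sapiens) for antiproliferative activity, read by sulforhodamine B assay, with a stated time of 4 days (on this read-out higher numbers stand for weaker inhibition of growth and lower numbers for stronger inhibition of growth), compound 1 `COc1cc(Cl)c(-c2nc(SCC(=O)NC(C)(C)C)nc3[nH]cc(C#N)c23)cc1O` gives 128 nM, compound 2 `COc1cc(Cl)c(-c2nc(SCC(=O)NC(C)(C)C)nc3[nH]cc(C#N)c23)cc1OC` gives 121 nM and compound 3 `COc1cc(Cl)c(-c2nc(SCC(=O)N3CCC3)nc3[nH]cc(C#N)c23)cc1O` gives 21 nM. Compound 2 stands level with compound 1 within the scatter, and both lie above compound 3. Compound 4 `CNC(=O)CSc1nc(-c2cc(OC)c(OC)cc2Cl)c2c(C#N)c[nH]c2n1` differs from compound 2 by methyl in place of tert-butyl on an amide-type nitrogen. Within the data shown here, two steps bear on this. The change on the oxygen, a 1.1-fold lower number from compound 1 to compound 2 (0.02 log units; within the scatter), stays within the scatter, so the amide trend should carry over to the dimethoxy compounds. Among the measured compounds shown here, replacing (tert-butyl)amino with azetidin-1-yl gives a 6.1-fold lower number from compound 1 to compound 3 (0.78 log units; beyond the scatter), the only amide evidence. Methylamino itself is untested, so a lower number in this assay is expected, though a somewhat smaller step. The estimated change is a 2.4-fold lower number from compound 2 to compound 4 (0.38 log units; beyond the scatter). For compound 4, the expected value is 50 nM, with an estimated range of 15 nM to 170 nM.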

Compound 4, concentration for 50% growth inhibition: 56 nM
Compound 4: the middle estimate sits 1.1-fold (0.05 log units) below what was measured, within the range that was stated.
By their numbers in this assay, from the lowest: compound 3; then compound 4; then compounds 2 and 1 (each within the scatter of the next).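

In this assay, replacing tert-butyl with methyl on the amide-type nitrogen gives a 2.2-fold lower number from compound 2 to compound 4 (0.33 log units; beyond the scatter). A lower number on leaving (tert-butyl)amino is therefore not tied to azetidin-1-yl, and it also appears on a dimethoxy compound, not only on the hydroxy compound. Nothing available explains this step.

As far as these compounds go, it remains open how ethylamino or dimethylamino would read on this carbonyl carbon. Also open, from the compounds shown here alone, is whether azetidin-1-yl would lower the number on the dimethoxy compound as well.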